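Methoxy Swapped for Hydroxymethyl: A Cytotoxicity Step to Estimate

The compounds below may be only part of what the source reports. "The series", "measured", "known", "first", "only" and "open" are said of these compounds alone.

Three compounds share one core and differ in a single group on an aromatic carbon. In an ADME assay on L1210/0 cells (Mus musculus) for cytotoxicity, with a stated time of 48 h (on this read-out higher numbers stand for weaker inhibition and lower numbers for stronger inhibition), compound 1 `N#CSc1cn([C@H]2C[C@H](O)[C@@H](CO)O2)c(=O)[nH]c1=O` gives 78900 nM, and compound 2 `[N-]=[N+]=NCc1cn([C@H]2C[C@H](O)[C@@H](CO)O2)c(=O)[nH]c1=O` gives 124000 nM. Compound 3 `COCC#Cc1cn([C@H]2C[C@H](O)[C@@H](CO)O2)c(=O)[nH]c1=O` gives > 200000 nM, which is a limit of the assay and not a number.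

Compound 4 `O=c1[nH]c(=O)n([C@H]2C[C@H](O)[C@@H](CO)O2)cc1C#CCCO` has the same atoms as compound 3, joined differently: hydroxymethyl in place of methoxy on a saturated chain carbon bound to a triple-bonded carbon. Put simply, hydroxymethyl stands in place of methoxy on a saturated chain carbon bound to a triple-bonded carbon.

Among the compounds with values here, no measured step makes this exact change, so the nearest guides are the swaps of the whole group. Azidomethyl in place of cyanosulfanyl gives a 1.6-fold higher number from compound 1 to compound 2 (0.20 log units; within the scatter). The 3-methoxyprop-1-yn-1-yl group gives an at least 2.5-fold higher number from compound 1 to compound 3 (0.40 log units; beyond the scatter) when it replaces cyanosulfanyl, and an at least 1.6-fold higher number from compound 2 to compound 3 (0.20 log units; that floor lies within the scatter) when it replaces azidomethyl. Those swaps change far more of the molecule than this one does, yet the steps stay small where they can be sized. No step beyond the scatter is therefore expected in this assay, and the estimated step is an at least 1.1-fold lower number from compound 3 to compound 4 (0.04 log units; that floor lies within the scatter). For compound 4 the expected value is 180000 nM, with an estimated range from 80000 nM to 300000 nM.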

Compound 4, half-maximal inhibitory concentration: > 200000 nM
Compound 4: a limit, no number; the forecaster's own chance of this, stated with the estimate: 55%; middle value at least 1.1-fold (0.04 log units) away from the limit.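

In this assay compound 4 gives > 200000 nM, which is a limit of the assay and not a number. Placing the 4-hydroxybut-1-yn-1-yl group on the aromatic carbon gives an at least 2.5-fold higher number from compound 1 to compound 4 (0.40 log units; beyond the scatter) when it replaces cyanosulfanyl, and an at least 1.6-fold higher number from compound 2 to compound 4 (0.20 log units; that floor lies within the scatter) when it replaces azidomethyl, so a group with one hydrogen-bond donor at this place shows the same floors as the 3-methoxyprop-1-yn-1-yl group of compound 3, which has none. The step from methoxy to hydroxymethyl itself cannot be read, and compound 3 and compound 4 cannot be ranked, since both rest on the same limit: the limit of > 200000 nM in this assay, at which 2 of the 4 values shown sit.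

As far as these compounds go, whether hydroxymethyl and methoxy differ at all on this saturated chain carbon therefore stays open, as any difference would lie out of reach of the read-out. Also open, from the compounds shown here alone, is whether another group, such as an amine or a carboxylic acid in place of the hydroxymethyl, or a longer chain, would bring the number back into the range where it can be read.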